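This account rests on a few compounds, and the source may have more. Where it says the series, first, only, none or still open, it means among the compounds named here.

Compound 1 `Cc1cccc(C)c1NC(=O)CSc1nnc(-c2ccoc2C)n1Cc1ccco1` carries a 2,6-dimethylphenyl group on the amide-type nitrogen of the shared core. In a functional assay on CHO cells for antagonist activity at Orexin receptor type 2 (Homo sapiens), read by FLIPR and calcium flux (on this read-out lower numbers stand for stronger inhibition and higher numbers for weaker inhibition), compound 1 gives > 15800 nM, which is a limit of the assay rather than a number (the limit of > 15800 nM in this assay, at which 1 of the 2 values shown sits). Compound 2 `Cc1occc1-c1nnc(SCC(=O)Nc2ccc(F)c(Cl)c2)n1Cc1ccco1` differs from compound 1 only in the group on that nitrogen, and in this assay compound 2 gives 39.8 nM. Within the data shown here, the single measured step, an at least 390-fold lower number from compound 1 to compound 2 (2.59 log units; beyond the scatter), shows that exchanging the 2,6-dimethylphenyl for another aryl group made a large difference here.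

Compound 3 `Cc1ccc(NC(=O)CSc2nnc(-c3ccoc3C)n2Cc2ccco2)cc1` has not yet been measured. Its change from compound 1 is 4-methylphenyl in place of 2,6-dimethylphenyl on an amide-type nitrogen. Among the measured compounds shown here, as in compound 2, the 2,6-dimethylphenyl group of compound 1 is replaced by a different aryl group, and the step from compound 1 to compound 2 is the only guide to its effect. A lower number than that of compound 1 is therefore expected for compound 3, though its size is uncertain. The expected step is an at least 39-fold lower number from compound 1 to compound 3 (1.59 log units; beyond the scatter). The estimate for compound 3 in this assay is 400 nM, with a range from 40 nM to 6000 nM.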

Compound 3, inhibition constant: 39.8 nM
Compound 3: the middle estimate sits 10-fold (1.00 log units) above what was measured; the whole stated range lies above it.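

In this assay, the change to a 4-methylphenyl group gives an at least 390-fold lower number from compound 1 to compound 3 (2.59 log units; beyond the scatter), so the large drop seen with compound 2 does not depend on the chlorine and fluorine of its 3-chloro-4-fluorophenyl group, since a group with carbon alone on the ring reaches the same printed value. The comparison of these two aryl groups gives no change at the digits printed from compound 2 to compound 3 (within the scatter), which means that two quite differently substituted rings on the amide-type nitrogen cannot be told apart in this assay, while the 2,6-dimethylphenyl group of compound 1 stands far from both. The value of compound 1 is a limit and not a number, so the full size of the step to compound 3 stays unknown: the limit of > 15800 nM in this assay, at which 1 of the 3 values shown sits.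

The compounds shown leave open whether the ring on this nitrogen needs any substituent at all, which a plain phenyl group would address, and whether it needs to be aromatic, which a cyclohexyl group would address. They also leave open what a carboxylic acid or an amine on that ring would do, and which feature of the 2,6-dimethylphenyl group sets compound 1 apart.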